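A Second Hydroxy Group Tried on Two Related Cores

This account rests on a few compounds, and the source may have more. Where it says the series, first, only, none or still open, it means among the compounds named here.

Compound 1 `COc1cc(/C=C/C(=O)C(=Cc2ccc(O)cc2)C(=O)/C=C/c2ccc(O)c(OC)c2)ccc1O` was examined in a functional assay on DLD-1 cells (Homo sapiens) for cytotoxicity, read by MTT assay (on this read-out higher numbers stand for weaker inhibition and lower numbers for stronger inhibition), where compound 1 gives 4080 nM. Compound 2 `COc1cc(/C=C/C(=O)C(=Cc2ccc(O)c(O)c2)C(=O)/C=C/c2ccc(O)c(OC)c2)ccc1O` carries one change relative to compound 1, which reads (hydroxy in place of hydrogen on an aromatic carbon). That change produced a 4.3-fold higher number from compound 1 to compound 2 (0.63 log units; beyond the scatter). Compound 3 `CCOc1cc(/C=C/C(=O)C(=Cc2ccc(O)cc2)C(=O)/C=C/c2ccc(O)c(OCC)c2)ccc1O` is built on a second core; the difference between the two cores is not broken down here. In this assay compound 3 gives 20300 nM, and compound 2 gives 17600 nM, the two lying within the usual scatter of each other. Compound 4 `CCOc1cc(/C=C/C(=O)C(=Cc2ccc(O)c(O)c2)C(=O)/C=C/c2ccc(O)c(OCC)c2)ccc1O` has not yet been measured. It differs from compound 3 by hydroxy in place of hydrogen on an aromatic carbon, the same change that separates compound 2 from compound 1, made at a place described in identical terms. Among the compounds with values here, the expected step is a 3.2-fold higher number from compound 3 to compound 4 (0.51 log units; beyond the scatter), an expectation that rests on the single earlier instance of this change, namely a 4.3-fold higher number from compound 1 to compound 2 (0.63 log units; beyond the scatter), and that carries the uncertainty of a change seen only once and now transferred to a different core. Compound 4 is therefore expected to give about 65000 nM, with a likely range from 25000 nM to 160000 nM.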

Compound 4, half-maximal inhibitory concentration: 5100 nM
The estimate for compound 4 lay 13-fold (1.11 log units) above the measured number; the whole stated range lies above it.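

In this assay, the change from 4-hydroxyphenyl to 3,4-dihydroxyphenyl on the second core gave a 4.0-fold lower number from compound 3 to compound 4 (0.60 log units; beyond the scatter), so the step ran opposite to the one on the core of compound 1. Set side by side, the two steps show that this change did not carry over from one core to the other, even in direction: the same change on two cores in this assay, a 4.3-fold higher number (0.63 log units; beyond the scatter) from compound 1 to compound 2 and a 4.0-fold lower number (0.60 log units; beyond the scatter) from compound 3 to compound 4, 17-fold (1.23 log units) apart, beyond the scatter of two such steps This does not show what in the two cores lies behind the reversal, and with a single pair on each core it gives no rule for any further core in this series.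

The compounds shown leave open whether an amine or a carboxylic acid in the same place, ortho to the hydroxy group, would split between the two cores in the same way as the hydroxy group does. They also leave open how the change would behave with a longer chain, such as propoxy, in place of the ethoxy groups of compound 3 and compound 4.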